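The compounds below may be only part of what the source reports. "The series", "measured", "known", "first", "only" and "open" are said of these compounds alone.

Measured so far:
compound 1, `O=C(O)CC/C=C\CO[C@H]1C(OCc2ccc(-c3ccccc3)cc2)CC[C@@H]1N1CCCCCC1`: 25.1 nM
compound 2, `O=C(O)CC/C=C\CO[C@@H]1C(OCc2ccc(-c3ccccc3)cc2)CC[C@@H]1N1CCCCC1`: 15.9 nM
compound 3, `O=C(O)CC/C=C\CO[C@H]1[C@@H](OCc2ccc(-c3ccccc3CO)cc2)CC[C@@H]1N1CCCCCC1`: 12.6 nM

All three were tested in a functional assay for antagonist activity at thromboxane A2 receptor (Rattus norvegicus); on this read-out lower numbers stand for tighter binding and higher numbers for weaker binding. Compound 1 has the highest of the three numbers, but compound 2 gives 15.9 nM and compound 3 gives 12.6 nM, and both lie within the scatter of compound 1, so none of the three can be called tighter or weaker than another. Compound 4, `NC(=O)c1ccccc1-c1ccc(COC2CC[C@H](N3CCCCCC3)[C@H]2OC/C=C\CCC(=O)O)cc1`, differs from compound 1 in one place: carbamoyl in place of hydrogen on an aromatic carbon. No change of this kind between measured compounds is available, so the step is expected to be small, if anything a slight drop in the number, and not beyond the scatter. Compound 4 is therefore expected to give 18 nM, between 8 nM and 45 nM. The expected step of a 1.4-fold lower number from compound 1 to compound 4 (0.14 log units; within the scatter) stays within the usual scatter.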

Compound 4, dissociation constant: 15.9 nM
The estimate for compound 4 lay 1.1-fold (0.05 log units) above the measured number; measured number inside the range.
By their numbers in this assay, from the lowest: compounds 3, 2, 4 and 1 (each within the scatter of the next).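

Placing carbamoyl in place of hydrogen on an aromatic carbon, ortho to a large group, gives a 1.6-fold lower number from compound 1 to compound 4 (0.20 log units; within the scatter) in this assay. Compound 1 and compound 4 therefore cannot be told apart on this read-out. This position on the ring accepts a group of this size, with a hydrogen-bond donor and acceptor, without a readable change in the number.

From the compounds shown here alone, whether a carboxylic acid, an aminomethyl group or a nitrile at the same place would also stay within the scatter remains open. Nothing available here bears on how the carbamoyl group is tolerated.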